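Doubly Charged Chain Variant Weighed Against Limit-Only Data

The source may report more compounds than this note shows. Statements on the series, on what has been measured and on what is new or still open speak of the compounds shown alone.

Compound 2 `Cc1cc(C)c2cccc(OCc3c(Cl)ccc(S(=O)(=O)NC4(C(=O)N5CCN(C(=O)C[C@@H](N)CCC[N+](C)(C)C)CC5)CCCC4)c3Cl)c2n1` is one of three close relatives examined in an assay on isolated protein for binding affinity to B1 bradykinin receptor (Homo sapiens); a lower number here means a stronger inhibitor, a higher number a weaker inhibitor. In this assay compound 2 gives < 10000 nM, which is a limit of the assay and not a number. Compound 1 `Cc1cc(C)c2cccc(OCc3c(Cl)ccc(S(=O)(=O)NC4(C(=O)N5CCN(C(=O)[C@H](CCCCN(C)C)N(C)C)CC5)CCCC4)c3Cl)c2n1` in this assay gives < 10000 nM, also a limit. Compound 3 `Cc1cc(C)c2cccc(OCc3c(Cl)ccc(S(=O)(=O)NC4(C(=O)N5CCN(C(=O)CCC[N+](C)(C)C)CC5)CCCC4)c3Cl)c2n1` in this assay gives < 10000 nM, again a limit. Compound 2 thus stands at the same limit as both relatives, with no number to set it apart.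

The change to compound 4 `Cc1cc(C)c2cccc(OCc3c(Cl)ccc(S(=O)(=O)NC4(C(=O)N5CCN(C(=O)[C@H](CCC[N+](C)(C)C)[N+](C)(C)C)CC5)CCCC4)c3Cl)c2n1` is a group of 12 heavy atoms (10 carbon, 2 nitrogen; no ring) in place of a group of 10 heavy atoms (8 carbon, 2 nitrogen; no ring), on a carbonyl carbon; the group that leaves has 1 hydrogen-bond donor, 1 hydrogen-bond acceptor and net charge +1, while the group that enters has 0 hydrogen-bond donors, 0 hydrogen-bond acceptors and net charge +2. The measured steps touching this region are a step that the two limits leave unreadable from compound 1 to compound 2, a step that the two limits leave unreadable from compound 1 to compound 3 and a step that the two limits leave unreadable from compound 2 to compound 3, all unreadable because of the limit of < 10000 nM in this assay, at which 3 of the 3 values shown sit. They give neither a size nor a direction for the step in this assay. Compound 4 is therefore expected to sit near 1000 nM, within a wide estimated range from 30 nM to 10000 nM. The expected step is a step that the limit leaves unreadable from compound 2 to compound 4.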

Compound 4, inhibition constant: < 10000 nM
Compound 4: no number, only a limit (the forecaster's own chance of this, stated with the estimate: 70%); the middle value does not contradict the limit.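

Within the data shown here, no step from compound 1, compound 2 or compound 3 to compound 4 can be read, because compound 4 also gives only a limit, the same one as the others: the limit of < 10000 nM in this assay, at which 4 of the 4 values shown sit. As far as these compounds go, whether these four compounds differ at all in this assay, and in which direction, stays open.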